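The compounds below may be only part of what the source reports. "The series", "measured", "known", "first", "only" and "open" are said of these compounds alone.

Of the compounds shown here, three have so far been measured in a functional assay on A498 cells (Homo sapiens) for cytotoxicity, read by sulforhodamine B assay, with a stated time of 48 h; on this read-out higher numbers stand for weaker inhibition of growth and lower numbers for stronger inhibition of growth. Compound 1 `ClCc1ccc(Cn2cnc3c(Cl)ncnc32)cc1` gives 26900 nM. Compound 2 `Nc1nc(Cl)c2ncn(Cc3ccc(CCl)cc3)c2n1` gives 85100 nM. Compound 3 `ClCc1ccccc1Cn1cnc2c(Cl)ncnc21` gives 32400 nM.

Compounds 1 and 2 differ in one place: amino in place of hydrogen on an aromatic carbon. That change brought a 3.2-fold higher number from compound 1 to compound 2 (0.50 log units; beyond the scatter) in this assay. Compounds 1 and 3 are built from the same atoms joined differently; the difference between the two cores is not broken down here, and their values in this assay lie within the scatter of each other.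

Compound 4 `Nc1nc(Cl)c2ncn(Cc3ccccc3CCl)c2n1` has not yet been measured. It stands to compound 3 as compound 2 stands to compound 1, the same change at the same place: amino in place of hydrogen on an aromatic carbon. For the measured compounds named here, because the one earlier example gave a 3.2-fold higher number from compound 1 to compound 2 (0.50 log units; beyond the scatter), compound 4 is expected to show a 3.1-fold higher number from compound 3 to compound 4 (0.49 log units; beyond the scatter) in this assay, though a single example is a thin basis. The estimate for compound 4 is 100000 nM, expected to fall between 45000 nM and 230000 nM.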

Compound 4, concentration for total growth inhibition: 44700 nM
Estimate against measurement, compound 4: 2.2-fold (0.35 log units) above; measured number outside the range, below it.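

In this assay, for the compounds shown here, amino in place of hydrogen on an aromatic carbon gave a 1.4-fold higher number from compound 3 to compound 4 (0.14 log units; within the scatter), so on this core the change produced no step clear of the usual scatter. Set beside the earlier step, the difference between the two is no larger than repeated measurements could produce: the same change on two cores in this assay, a 3.2-fold higher number (0.50 log units; beyond the scatter) from compound 1 to compound 2 and a 1.4-fold higher number (0.14 log units; within the scatter) from compound 3 to compound 4, 2.3-fold (0.36 log units) apart, within the scatter of two such steps. This shows no firm dependence on the core, but it does not show that the step carries over unchanged, since two pairs, one of them within the scatter, are too few to settle either reading.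

On these data alone, it remains open whether a methylamino or a methoxy group on the same aromatic carbon would move the number on either core.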